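The compounds below may be only part of what the source reports. "The series", "measured", "known", "first", "only" and "open" are said of these compounds alone.

Measured compounds in a functional assay on OVCAR-5 cells (Homo sapiens) for inhibition, read by sulforhodamine B assay, with a stated time of 48 h; on this read-out higher numbers stand for weaker inhibition of growth and lower numbers for stronger inhibition of growth:
Compound 1 `COc1cc(-c2cc(/C=C/C(=O)c3ccc(Cl)c(Cl)c3)[nH]n2)cc(OC)c1OC` gives 20500 nM.
Compound 2 `COc1ccc(-c2cc(/C=C/C(=O)c3cc(OC)c(OC)c(OC)c3)[nH]n2)cc1OC` gives 1760 nM.
Compound 3 `COc1ccc(C(=O)/C=C/c2cc(-c3cc(OC)c(OC)c(OC)c3)n[nH]2)cc1` gives 1880 nM.

Compound 3 stands second highest of the three numbers. Its nearest neighbour is compound 2, whose value lies within the scatter of that of compound 3, so no order can be read between the two. For the measured compounds named here, its furthest neighbour is compound 1, reached by the one step that differs in a single place: an 11-fold lower number from compound 1 to compound 3 (1.04 log units; beyond the scatter).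

Compound 4 `COc1cc(-c2cc(/C=C/C(=O)c3ccc(F)c(F)c3)[nH]n2)cc(OC)c1OC` has not yet been measured. It differs from compound 3 in one place: 3,4-difluorophenyl in place of 4-methoxyphenyl on a carbonyl carbon.

Going by the values given here, the only step that bears on this change is the one from compound 1 to compound 3, which exchanged a dihalogenated phenyl for 4-methoxyphenyl at the same carbonyl carbon and gave a large drop in the number. Compound 4 reverses that exchange in kind, with 3,4-difluorophenyl instead of 3,4-dichlorophenyl, so a step upward in this assay is expected, though the different halogen leaves its size uncertain. The expected step is a 4.3-fold higher number from compound 3 to compound 4 (0.63 log units; beyond the scatter). Compound 4 is thus estimated at 8000 nM, with a range from 3000 nM to 22000 nM.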

Compound 4, concentration for 50% growth inhibition: 4480 nM
Compound 4: the middle estimate sits 1.8-fold (0.25 log units) above what was measured; the range from low to high includes it.
By their numbers in this assay, from the lowest: compounds 2 and 3 (each within the scatter of the next); then compound 4; then compound 1.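

In this assay, the group on a carbonyl carbon now has three members on one core, and the identity of the halogen matters as well as its presence: 3,4-difluorophenyl in place of 3,4-dichlorophenyl gives a 4.6-fold lower number from compound 1 to compound 4 (0.66 log units; beyond the scatter), yet the same group in place of 4-methoxyphenyl still gives a 2.4-fold higher number from compound 3 to compound 4 (0.38 log units; beyond the scatter). Among these three compounds, the number rises from 4-methoxyphenyl through 3,4-difluorophenyl to 3,4-dichlorophenyl, with no compound going against that order. No measurement in hand accounts for this order.

Three groups cannot show whether the order extends to other phenyl groups at this carbonyl carbon, such as 4-aminophenyl or 4-hydroxyphenyl. On these data alone, whether an unsubstituted phenyl or a single fluorine on the phenyl would fall within this range also remains open.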